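The compounds below may be only part of what the source reports. "The series", "measured", "known", "first", "only" and "open" are said of these compounds alone.

Measured compounds:
compound 1 `COc1ccc2[nH]c(-c3ccc[nH]3)c(C3CC(=O)NC3=O)c2c1`: 4000 nM
compound 2 `COc1ccc2[nH]c(-n3cccn3)cc2c1`: > 100000 nM
compound 3 `Cc1ccc2[nH]c(-c3ccc[nH]3)c(C3CC(=O)NC3=O)c2c1`: 20000 nM

In a functional assay on A549 cells (Homo sapiens) for cytotoxicity, read by MTT assay, with a stated time of 72 h (on this read-out lower numbers stand for stronger inhibition and higher numbers for weaker inhibition), compound 1 gives 4000 nM. Compound 3 carries the same core with one change, (methyl in place of methoxy on an aromatic carbon), and in this assay compound 3 gives 20000 nM, so that the step of a 5.0-fold higher number from compound 1 to compound 3 (0.70 log units; beyond the scatter). Compound 2 belongs to a different series; the difference between its core and that of compound 1 is not broken down here. For compound 2 this assay reports only a limit, > 100000 nM, and this limit is the same as the limit of > 100000 nM in this assay, at which 1 of the 3 values shown sits.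

Compound 4 `Cc1ccc2[nH]c(-n3cccn3)cc2c1` is not yet measured. It differs from compound 2 by methyl in place of methoxy on an aromatic carbon, which is the same change as that from compound 1 to compound 3, made at the same place. Since that earlier step raised the number, the step that the limit leaves unreadable from compound 2 to compound 4 is expected to point in the same direction, if it can be read at all. Because compound 2 already sits at the limit > 100000 nM, compound 4 is expected to give 200000 nM, most likely also reported only as a limit, within a range from 60000 nM to 1000000 nM.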

Compound 4, half-maximal inhibitory concentration: > 100000 nM
Compound 4 was reported as a limit; the forecaster's own chance of this, stated with the estimate: 90%; the middle value is on the limit's open side.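

In this assay compound 4 gives only a limit, > 100000 nM. Compound 2 also stands at a limit, so no step between compound 2 and compound 4 can be read: the limit of > 100000 nM in this assay, at which 2 of the 4 values shown sit.

The compounds shown leave open whether methyl in place of methoxy changes the number at all for compound 2 and compound 4.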